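The source may report more compounds than this note shows. Statements on the series, on what has been measured and on what is new or still open speak of the compounds shown alone.

Measured so far in a physicochemical assay for solubility, measured as kinetic solubility; a lower number here means a less soluble compound, a higher number a more soluble compound:
- compound 1 `Cc1ccc(S(=O)(=O)Nc2ccc(CN(C)[C@@H]3CCN(C(=O)c4cccc(Cl)c4)C3)cc2)cc1`: 28000 nM
- compound 2 `COc1ccc(S(=O)(=O)Nc2ccc(CN3C[C@@H]4C[C@H]3CN4C(=O)c3cccc(Cl)c3)cc2)cc1`: 47000 nM

Only these two numbers are available, and they lie within the usual scatter of repeated measurements, so this assay cannot tell compound 1 and compound 2 apart. Going by the values given here, compound 1 therefore stands level with the only other compound measured.

The next compound is compound 3 `Cc1ccc(S(=O)(=O)Nc2ccc(CN(C)[C@H]3CCN(C(=O)c4cccc(Cl)c4)C3)cc2)cc1`, and the change from compound 1 is the two compounds have the same atoms and bonds and differ only in configuration as drawn: 1 of 1 stereo elements differ; a stereocentre at a saturated ring carbon is drawn R in compound 1 and S in compound 3. Nothing leaves and nothing enters: the two compounds have the same atoms and bonds, and a stereocentre at a saturated ring carbon is drawn R in compound 1 and S in compound 3.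

Among the compounds with values here, no measured pair shows what such a switch does in this assay, so the expectation rests on compound 1 itself, at 28000 nM, and on the identical atoms and bonds. No step beyond the scatter is expected, in either direction. The expected change is a 1.1-fold higher number from compound 1 to compound 3 (0.03 log units; within the scatter). For compound 3 the estimated value is 30000 nM, with an expected range from 16000 nM to 52000 nM.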

Compound 3, solubility: 27000 nM
The estimate for compound 3 lay 1.1-fold (0.05 log units) above the measured number; measured number inside the range.
By their numbers in this assay, from the lowest: compounds 3, 1 and 2 (each within the scatter of the next).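

In this assay, going by these compounds alone, turning this one stereocentre at a saturated ring carbon from R to S gives a 1.0-fold lower number from compound 1 to compound 3 (0.02 log units; within the scatter), so the switch leaves no step that this read-out can resolve. Compound 1 and compound 2 differ in more than one place and could not isolate any single change, whereas this pair can be read directly because nothing else separates the two structures: the fact that compounds 1 and 3 differ only in the configuration as drawn. For this pair, then, the drawn configuration at this position makes no measurable difference in this assay, and either form can serve as the reference for later comparisons in this assay.

The compounds shown leave open whether the two configurations would still read alike in this assay if a new group, such as a carboxylic acid or a hydroxyl, were added to the shared core. They also leave open whether a switch of configuration in the core of compound 2 would likewise give a step within the scatter, as this single pair speaks only for the core of compound 1.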